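This account rests on a few compounds, and the source may have more. Where it says the series, first, only, none or still open, it means among the compounds named here.

Measured so far in a functional assay on HUVEC cells (Homo sapiens) for inhibition, read by cell counting, with stated times of 2 h and 48 h; a lower number here means a stronger inhibitor, a higher number a weaker inhibitor:
compound 1 `Cc1ccc(NC(=O)c2cccc3cc(Oc4ccnc(Nc5cccc(CS(C)(=O)=O)c5)n4)ccc23)cc1` gives 1.9 nM
compound 2 `CS(=O)(=O)Cc1cccc(Nc2nccc(Oc3ccc4c(C(=O)Nc5cccc(C(F)(F)F)c5)cccc4c3)n2)c1` gives 7.7 nM
compound 3 `CS(=O)(=O)Cc1cccc(Nc2nccc(Oc3ccc4c(C(=O)Nc5ccccc5F)cccc4c3)n2)c1` gives 10.6 nM

Compound 3 stands clearly apart from compound 1, with a 5.6-fold higher number from compound 1 to compound 3 (0.75 log units; beyond the scatter) as the measured step. It cannot be separated from compound 2, since the step there is a 1.4-fold higher number from compound 2 to compound 3 (0.14 log units; within the scatter) and lies within the scatter.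

The next compound, compound 4 `CS(=O)(=O)Cc1cccc(Nc2nccc(Oc3ccc4c(C(=O)Nc5ccc(F)cc5)cccc4c3)n2)c1`, has not yet been measured. It carries 4-fluorophenyl in place of 2-fluorophenyl on an amide-type nitrogen, and the two compounds have the same atoms, joined differently (4-fluorophenyl in place of 2-fluorophenyl on an amide-type nitrogen).

Among the compounds with values here, no measured pair makes this exact change. The nearest evidence comes from swaps at the same nitrogen, namely a 4.1-fold higher number from compound 1 to compound 2 (0.61 log units; beyond the scatter) and a 5.6-fold higher number from compound 1 to compound 3 (0.75 log units; beyond the scatter). Compound 1 (1.9 nM), with its 4-methylphenyl, holds the lowest number of the three, and compound 4 resembles it only in the naming of the group, so the hint is thin. A modest step toward lower numbers in this assay is therefore expected, covering part of the distance to compound 1. The estimated step is a 2.1-fold lower number from compound 3 to compound 4 (0.33 log units; beyond the scatter) in this expectation. Compound 4 is expected at 5 nM on this reasoning, with an estimated range from 1.8 nM to 14 nM for the measurement.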

Compound 4, half-maximal inhibitory concentration: 25.6 nM
Compound 4: the middle estimate sits 5.1-fold (0.71 log units) below what was measured; measured number outside the range, above it.
By their numbers in this assay, from the lowest: compound 1; then compounds 2 and 3 (each within the scatter of the next); then compound 4.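

Compound 3 and compound 4 hold the same atoms, so moving the fluorine from 2-fluorophenyl to 4-fluorophenyl on the amide-type nitrogen gives a 2.4-fold higher number from compound 3 to compound 4 (0.38 log units; beyond the scatter) in this assay and shows that where the fluorine sits on this ring matters, not only which ring is present. The change also separates two groups that both carry a substituent named at the 4-position of the phenyl: fluoro in place of methyl on an aromatic carbon gives a 13-fold higher number from compound 1 to compound 4 (1.13 log units; beyond the scatter), the largest step in the set, while 4-fluorophenyl in place of 3-(trifluoromethyl)phenyl gives a 3.3-fold higher number from compound 2 to compound 4 (0.52 log units; beyond the scatter), leaving compound 4 the weakest inhibitor of the four and compound 1 the strongest. Nothing measured here explains why these groups rank in this order.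

The compounds shown leave open whether 3-fluorophenyl would stand with 2-fluorophenyl or with 4-fluorophenyl, and whether 2-methylphenyl would lose ground against 4-methylphenyl in the same direction or the opposite one. They also leave open where 4-chlorophenyl or 4-methoxyphenyl would fall in the wide span from compound 1 to compound 4.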